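Varying the aryl group on the ring nitrogen

A few compounds are considered here, and "the series" means these few. Any claim that something is new, unique, unknown or untested is made for them only; others in the source may bear on it.

Measured compounds in a functional assay for antagonist activity at transient receptor potential cation channel subfamily V member 1 (Homo sapiens), read by FLIPR and calcium flux; on this read-out higher numbers stand for weaker inhibition and lower numbers for stronger inhibition:
compound 1, `O=C1COc2ccc(NC(=O)C3CCN(c4ccccc4Br)CC3)cc2N1`: 160 nM
compound 2, `COc1cccc(N2CCC(C(=O)Nc3ccc4c(c3)NC(=O)CO4)CC2)c1`: 1420 nM
compound 3, `O=C1COc2ccc(NC(=O)C3CCN(c4ccccc4C(F)(F)F)CC3)cc2N1`: 380 nM

Compound 3 stands second highest of the three numbers. Compound 1 is its nearest neighbour, with a 2.4-fold higher number from compound 1 to compound 3 (0.38 log units; beyond the scatter); compound 2 is furthest, with a 3.7-fold lower number from compound 2 to compound 3 (0.57 log units; beyond the scatter).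

The next compound is compound 4, `Cc1cccc(N2CCC(C(=O)Nc3ccc4c(c3)NC(=O)CO4)CC2)c1C`. The change from compound 3 is 2,3-dimethylphenyl in place of 2-(trifluoromethyl)phenyl on an amine nitrogen in a ring.

Within the data shown here, two measured steps bear on it, both exchanges of the aryl group on the same ring nitrogen: an 8.9-fold higher number from compound 1 to compound 2 (0.95 log units; beyond the scatter) and a 3.7-fold lower number from compound 2 to compound 3 (0.57 log units; beyond the scatter). Both are modest but beyond the scatter, so the aryl group does move the number within this small set. The aryl groups carrying a group on the carbon named 2 in the printed names (compound 1, compound 3) gave lower numbers than the 3-methoxyphenyl of compound 2. Among the measured compounds shown here, compound 4 carries groups at both positions named in 2,3-dimethylphenyl, with no direct precedent, so the direction is uncertain; a step of modest size, not larger than those seen, is expected, a 1.3-fold lower number from compound 3 to compound 4 (0.10 log units; within the scatter).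

Compound 4 is therefore estimated at 300 nM in this assay, with a range from 100 nM to 1000 nM.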

Compound 4, half-maximal inhibitory concentration: 60 nM
For compound 4 the middle estimate is 5.0-fold (0.70 log units) above the measured one; measured number below the stated range.
By their numbers in this assay, from the lowest: compound 4; then compound 1; then compound 3; then compound 2.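

In this assay, compound 4 has the lowest number of the four, and all three steps to it lie beyond the scatter: a 2.7-fold lower number from compound 1 to compound 4 (0.43 log units; beyond the scatter) and a 6.3-fold lower number from compound 3 to compound 4 (0.80 log units; beyond the scatter) and a 24-fold lower number from compound 2 to compound 4 (1.37 log units; beyond the scatter). Among these compounds, on this amine nitrogen in a ring, 2,3-dimethylphenyl therefore gives a lower number than 2-bromophenyl, 2-(trifluoromethyl)phenyl or 3-methoxyphenyl, so neither bromo nor trifluoromethyl is needed for a low number, and the exchange from 3-methoxyphenyl gives the only large step among the new ones. Nothing available accounts for why this aryl group gives the lowest number.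

The compounds shown leave open whether a single methyl group, as in 2-methylphenyl or 3-methylphenyl, would account for the lower number or whether both methyl groups are required. They also leave open how 2,3-dichlorophenyl, or a pyridine ring in place of the phenyl ring, would compare on the same nitrogen, and whether the order of these aryl groups would hold with any change to the shared core.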